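A few compounds are considered here, and "the series" means these few. Any claim that something is new, unique, unknown or untested is made for them only; others in the source may bear on it.

Working notes on the series. Three compounds sharing the core of compound 1 `CCNC1=Nc2ccc(Cl)cc2C(C)(C)C1` have been run in a functional assay on MDA-MB-231 cells (Homo sapiens) for cytotoxicity, read by MTT assay, with a stated time of 72 h, tested at 1 uM, in the absence of a further agent; a higher number here means a weaker effect of the compound at the concentration tested, a lower number a stronger effect; in that assay compound 1 gives 89.7%. Compound 2 `CCCNC1=Nc2ccc(Cl)cc2C(C)(C)C1` gives 90.7% in this assay, and compound 3 `CC1(C)CC(NCc2ccccc2)=Nc2ccc(Cl)cc21` gives 88.8%. The three numbers sit together: the step of a number 1 percentage points higher from compound 1 to compound 2 (within the scatter), the step of a number 0.9 percentage points lower from compound 1 to compound 3 (within the scatter) and the step of a number 1.9 percentage points lower from compound 2 to compound 3 (within the scatter) all stay within the scatter, so compound 3 is indistinguishable from compounds 1 and 2 on these readings, and all three leave most of the cells alive at the concentration tested.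

Compound 4 `CC1(C)CC(NCCCO)=Nc2ccc(Cl)cc21` has not been measured. Relative to compound 3 the change is 2-hydroxyethyl in place of phenyl on a saturated chain carbon bound to an amine nitrogen. Among the measured compounds shown here, no measured step on this core touches the group bound to the amine nitrogen in a way that moves the number: the swaps among ethyl, propyl and benzyl (a number 0.9 percentage points lower from compound 1 to compound 3 (within the scatter) and a number 1.9 percentage points lower from compound 2 to compound 3 (within the scatter)) were flat. The replacement of phenyl by 2-hydroxyethyl is a different kind of change, and nothing measured bears on it directly, so the expectation is a step of no size beyond the scatter in this assay, taken as a number 1.2 percentage points higher from compound 3 to compound 4 (within the scatter).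

For compound 4 the estimated value in this assay is 90%, expected between 78% and 100%.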

Compound 4, a percentage reported as activity, at one concentration (the size of the read-out at that concentration, not a potency): 84.5%
Beside the measured number, compound 4's estimate is 5.5 percentage points above it, and the stated range covers the measured number.
By their numbers in this assay, from the lowest: compounds 4, 3, 1 and 2 (each within the scatter of the next).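

On a saturated chain carbon bound to an amine nitrogen, a chain ending in hydroxy reads in this assay like the groups without one, with a number 4.3 percentage points lower from compound 3 to compound 4 (within the scatter) and, on the same core, a number 6.2 percentage points lower from compound 2 to compound 4 (within the scatter) and a number 5.2 percentage points lower from compound 1 to compound 4 (within the scatter) as well. The flat picture among ethyl, propyl and benzyl therefore extends to a group that carries a hydrogen-bond donor and a hydrogen-bond acceptor and no ring, so at the single concentration tested neither the ring of the benzyl group nor the presence of hydroxy separates these compounds. No supporting evidence bears on this result.

The compounds shown leave open whether an amine or a carboxylic acid at the end of the chain, or a longer chain, would move the reading in this assay beyond the scatter. They also leave open whether the four compounds would still read alike at any other concentration, given that each reading here is a single-concentration value and not a potency.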